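A Bromine Added to the Aryl Ring of Compound 1

The compounds below may be only part of what the source reports. "The series", "measured", "known", "first", "only" and "open" are said of these compounds alone.

Of the compounds shown here, two from this series have been tested in a functional assay on HL-60 cells (Homo sapiens) for cytotoxicity, read by CCK-8 assay, with a stated time of 72 h; on this read-out lower numbers stand for stronger inhibition and higher numbers for weaker inhibition. Compound 1, `C=CCn1c(=O)/c(=C\c2cccc(F)c2)[nH]c(=O)/c1=C\c1ccccc1OC`, gives 8890 nM in this assay, the higher of the two numbers recorded. Compound 2, `COc1ccccc1/C=c1\c(=O)[nH]/c(=C/c2ccccc2Cl)c(=O)n1C`, gives 200 nM in this assay, a much lower number, and the gap between the two lies well beyond the usual scatter of repeated measurements. The two structures differ in several places at once, so the numbers alone cannot say which part of the difference matters.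

Compound 3, `C=CCn1c(=O)/c(=C\c2ccc(F)c(Br)c2)[nH]c(=O)/c1=C\c1ccccc1OC`, has not yet been measured in this assay. It differs from compound 1 in a single place: 3-bromo-4-fluorophenyl in place of 3-fluorophenyl on a double-bonded chain carbon bound to an aromatic carbon. Nothing measured here shows what adding a bromine to this ring does, so the expectation rests on compound 1 alone. A step of a 1.8-fold lower number from compound 1 to compound 3 (0.25 log units; within the scatter) is expected, a change that may not exceed the scatter. In this assay compound 3 is therefore expected to give about 5000 nM, in a range from 1500 nM to 15000 nM.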

Compound 3, half-maximal inhibitory concentration: "not active" (no number reported)
Compound 3 has no reported number here; there is nothing to compare the estimate with.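

In this assay, for the compounds shown here, compound 3 is reported as not active, with no number, so no step from compound 1 to compound 3 can be read. No other measurement here bears on this result. The compounds shown leave open how far 3-bromo-4-fluorophenyl in place of 3-fluorophenyl shifts the number on this core.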